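The compounds below may be only part of what the source reports. "The series", "measured", "known", "first", "only" and "open" are said of these compounds alone.

In a functional assay on MCF7 cells (Homo sapiens) for cytotoxicity, read by MTT assay, with a stated time of 48 h (a lower number here means a stronger inhibitor of growth, a higher number a weaker inhibitor of growth), compound 1 `Cc1nc2cc(Cl)c(Cl)cc2[nH]1` gives 28000 nM and compound 2 `CC(C)c1nc2cc(Cl)c(Cl)cc2[nH]1` gives 57000 nM on the same read-out. Compound 3 `CCn1c(C(F)(F)F)nc2cc(Cl)c(Cl)cc21` gives 72900 nM in this assay as well. That number lies within the scatter of compound 2 and, beyond the scatter, higher than the number of compound 1.

Compound 4 `C=CCn1c(C(F)(F)F)nc2cc(Cl)c(Cl)cc21` differs from compound 3 by a single change, vinyl in place of methyl on a saturated chain carbon bound to an aromatic nitrogen in short: vinyl in place of methyl on a saturated chain carbon bound to an aromatic nitrogen. Cut one bond further out, the same difference reads ethyl to allyl.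

Going by the values given here, no measured step touches that place. Among the compounds with values here, the only step at hand ends at compound 2, with a 2.0-fold higher number from compound 1 to compound 2 (0.31 log units; beyond the scatter) for isopropyl in place of methyl on an aromatic carbon. It is modest, sits at a different place in the molecule, and can guide the expectation only loosely. On that footing the expected size is a 1.1-fold lower number from compound 3 to compound 4 (0.05 log units; within the scatter) in this assay and no clear direction is expected, so the change should stay within the scatter. For compound 4 the estimated value is 65000 nM with an expected range from 32000 nM to 130000 nM in this estimate.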

Compound 4, concentration for 50% growth inhibition: 87000 nM
Beside the measured number, compound 4's estimate is 1.3-fold (0.13 log units) below it; the range from low to high includes it.
By their numbers in this assay, from the lowest: compound 1; then compounds 2, 3 and 4 (each within the scatter of the next).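

Vinyl in place of methyl on a saturated chain carbon bound to an aromatic nitrogen gives, in this assay, a 1.2-fold higher number from compound 3 to compound 4 (0.08 log units; within the scatter), so at this place the change from ethyl to allyl leaves the read-out within the scatter. Going by these compounds alone, the earlier compounds offered no step at this place; their one step, a 2.0-fold higher number from compound 1 to compound 2 (0.31 log units; beyond the scatter), lay on an aromatic carbon and went beyond the scatter, whereas the new step does not, and so the chain on this nitrogen accepts this one change without a shift that can be told from repeat measurement. Nothing in the available data accounts for this result or bears on it.

One change at one place says little about how far that chain can be altered, and a longer chain, a benzyl group, or a chain ending in an amine or a carboxylic acid remains an open case. Compound 3 and compound 4 also share trifluoromethyl on the aromatic carbon, so the compounds shown leave open whether the change from ethyl to allyl would read the same with methyl or isopropyl there.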